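This account rests on a few compounds, and the source may have more. Where it says the series, first, only, none or still open, it means among the compounds named here.

Measured compounds:
compound 1, `COc1ccc(C2CC(c3ccc(NC(=O)c4cc(Cl)ccc4OC)cc3)=NN2C)cc1`, 69.6%
compound 2, `COc1ccc(Cl)cc1C(=O)Nc1ccc(C2=NN(C)C(c3ccccc3[N+](=O)[O-])C2)cc1`, 83.8%
compound 3, `COc1ccc(C2CC(c3ccc(NC(=O)c4cc(Cl)ccc4OC)cc3)=NN2)cc1`, 70.6%

All three values come from a functional assay on the whole organism (plasma, strain albino) for inhibition, with Rattus norvegicus as the target, with stated times of 1 h and 4 h, at a dose of 25 mg/kg by the oral route; on this read-out lower numbers stand for a weaker effect and higher numbers for a stronger effect at the one dose given. Compound 4, `COc1ccc(Cl)cc1C(=O)Nc1ccc(C2=NNC(c3ccccc3[N+](=O)[O-])C2)cc1`, is not yet measured in this assay.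

The cores of compound 1 and compound 3 differ by hydrogen in place of methyl on an amine nitrogen in a ring; the step of a number 1 percentage points higher from compound 1 to compound 3 (within the scatter).

Within the core of compound 1, the change 2-nitrophenyl in place of 4-methoxyphenyl on a saturated ring carbon gave a number 14.2 percentage points higher from compound 1 to compound 2 (beyond the scatter).

The same kind of change is made from compound 3 to compound 4: 2-nitrophenyl in place of 4-methoxyphenyl on a saturated ring carbon. The places are not identical: in compound 1 the saturated ring carbon is also next to the ring atom that bears a methyl group (1 heavy atom), whereas in compound 3 it is not.

For compound 4 a step of a number 13.4 percentage points higher from compound 3 to compound 4 (beyond the scatter) is expected, because a number 14.2 percentage points higher from compound 1 to compound 2 (beyond the scatter) was obtained under the same kind of change, and because a number 1 percentage points higher from compound 1 to compound 3 (within the scatter) suggests the core difference matters little here.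

Compound 4 is therefore estimated at 84%, between 74% and 93%.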

Compound 4, a percentage reported as inhibition, in the whole organism at one dose (the size of the read-out at that dose, not a potency): 72.3%
For compound 4 the middle estimate is 11.7 percentage points above the measured one; measured number outside the range, below it.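

In this assay, 2-nitrophenyl in place of 4-methoxyphenyl on the saturated ring carbon gives a number 1.7 percentage points higher from compound 3 to compound 4 (within the scatter), and set beside the step on the core of compound 1 it does not separate from it: the same change on two cores in this assay, a number 14.2 percentage points higher (beyond the scatter) from compound 1 to compound 2 and a number 1.7 percentage points higher (within the scatter) from compound 3 to compound 4, 12.5 percentage points apart, within the scatter of two such steps. Hydrogen in place of methyl on the ring nitrogen gives a number 11.5 percentage points lower from compound 2 to compound 4 (beyond the scatter), and the comparison with the same change on the other core reads alike: the same change on two cores in this assay, a number 1 percentage points higher (within the scatter) from compound 1 to compound 3 and a number 11.5 percentage points lower (beyond the scatter) from compound 2 to compound 4, 12.5 percentage points apart, within the scatter of two such steps. With a single pair on each core, this neither shows that the gain carries from one core to the other nor shows that the core alters it.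

Open, from the compounds shown here alone, is how a longer chain in place of methyl on the ring nitrogen would read. Also open, going by these compounds, is how a phenyl bearing an amine or a carboxylic acid on the saturated ring carbon would read on either core.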